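The source may report more compounds than this note shows. Statements on the series, on what has been measured and on what is new or still open speak of the compounds shown alone.

Compound 1, with the structure `c1ccc(Sc2ccc(NC3=NCCN3)cc2)cc1`, was tested in an assay (Rattus norvegicus) for binding affinity to prostacyclin receptor (Homo sapiens), read by radioligand binding (a lower number here means a stronger inhibitor, a higher number a weaker inhibitor), where compound 1 gives 794 nM. Two close relatives were measured alongside it. Compound 2, `COc1ccccc1Sc1ccc(NC2=NCCN2)cc1`, gives 3980 nM, and compound 3, `COc1cccc(Sc2ccc(NC3=NCCN3)cc2)c1`, gives 398 nM. Compound 1 therefore stands second highest of the three numbers: the change a 2.0-fold lower number from compound 1 to compound 3 (0.30 log units; within the scatter), whereas the change a 5.0-fold higher number from compound 1 to compound 2 (0.70 log units; beyond the scatter). Compound 4, `O=C(O)c1ccc(Sc2ccc(NC3=NCCN3)cc2)cc1`, differs from compound 1 by carboxy in place of hydrogen on an aromatic carbon. Among the compounds with values here, no measured step introduces a carboxy group, and the two methoxy steps run in opposite directions, one modest rise and one within the scatter. Compound 4 is thus expected to give about 1000 nM, within 300 nM to 3200 nM. This estimate means a 1.3-fold higher number from compound 1 to compound 4 (0.10 log units; within the scatter), expected to be small.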

Compound 4, inhibition constant: < 10000 nM
Compound 4: a limit, no number; the forecaster's own chance of this, stated with the estimate: 5%; the middle value does not contradict the limit.
By their numbers in this assay, from the lowest: compounds 3 and 1 (each within the scatter of the next); then compound 2.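

In this assay, within the data shown here, compound 4 gives < 10000 nM, which is a limit and not a number, so no step from compound 1 to compound 4 can be read. The compounds shown leave open whether carboxy in place of hydrogen changes the number at all, and by how much.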